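Dimethoxyphenyl in Place of Bromophenyl: an Estimate

The compounds below may be only part of what the source reports. "The series", "measured", "known", "first", "only" and "open" are said of these compounds alone.

Compound 1 `CN(C)CCn1cnnc1-c1cc(Oc2ccc(NC(=O)N/N=C/c3cccc(Br)c3)cc2F)ccn1` stands highest of the two numbers reported in a functional assay on A549 cells (Homo sapiens) for cytotoxicity, read by MTT assay, with a stated time of 72 h (on this read-out higher numbers stand for weaker inhibition and lower numbers for stronger inhibition), where compound 1 gives 970 nM. Its nearest neighbour is compound 3 `CN(C)CCn1cnnc1-c1cc(Oc2ccc(NC(=O)N/N=C/c3c[nH]c4ccccc34)cc2F)ccn1`, and in this assay compound 3 gives 820 nM, so that the step of a 1.2-fold lower number from compound 1 to compound 3 (0.07 log units; within the scatter) is within the scatter. Compound 2 `CN(C)CCn1cnnc1-c1cc(Oc2ccc(NC(=O)N/N=C/c3ccc(O)c(O)c3)cc2F)ccn1` gives in this assay only > 100000 nM, which is a limit of the assay and not a number. That limit is the limit of > 100000 nM in this assay, at which 1 of the 3 values shown sits. The step of an at least 100-fold higher number from compound 1 to compound 2 (2.01 log units; beyond the scatter) is therefore large, whereas the step of an at least 120-fold lower number from compound 2 to compound 3 (2.08 log units; beyond the scatter) runs the other way and is equally large.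

Compound 4 `COc1ccc(/C=N/NC(=O)Nc2ccc(Oc3ccnc(-c4nncn4CCN(C)C)c3)c(F)c2)c(OC)c1` differs from compound 1 in one place (2,4-dimethoxyphenyl in place of 3-bromophenyl on a carbon with a double bond to nitrogen). The entering 2,4-dimethoxyphenyl carries 0 hydrogen-bond donors and 2 hydrogen-bond acceptors, so the two measured steps on this carbon offer only partial guidance: the 3,4-dihydroxyphenyl of compound 2 abolished activity, while the 1H-indol-3-yl of compound 3 left it unchanged. A modest weakening is expected rather than a collapse. Compound 4 is estimated to give about 1500 nM in this assay, within a range from 400 nM to 8000 nM. This estimate corresponds to an expected step of a 1.5-fold higher number from compound 1 to compound 4 (0.19 log units; within the scatter), close to the scatter and toward a higher number.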

Compound 4, half-maximal inhibitory concentration: 2820 nM
Estimate against measurement, compound 4: 1.9-fold (0.27 log units) below, and the stated range covers the measured number.
By their numbers in this assay, from the lowest: compounds 3 and 1 (each within the scatter of the next); then compound 4. At a limit, above all of these: compound 2.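

Going by these compounds alone, the 2,4-dimethoxyphenyl gives this carbon its first intermediate step in this assay, a 2.9-fold higher number from compound 1 to compound 4 (0.46 log units; beyond the scatter), where the earlier steps from compound 1 were either within the scatter or large. The 1H-indol-3-yl group also keeps its edge over the new group, with a 3.4-fold higher number from compound 3 to compound 4 (0.54 log units; beyond the scatter), while the other comparison, an at least 35-fold lower number from compound 2 to compound 4 (1.54 log units; beyond the scatter), leaves the 2,4-dimethoxyphenyl far nearer to the two active compounds than to the 3,4-dihydroxyphenyl. Oxygen on the phenyl ring therefore does not by itself end the activity, although the comparison with compound 2 rests on a limit of the assay and not a number: the limit of > 100000 nM in this assay, at which 1 of the 4 values shown sits.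

The compounds shown leave open whether the step to compound 4 follows from the methoxy groups themselves or from where they sit on the ring, a question that a 3,4-dimethoxyphenyl group, set against both compound 2 and compound 4, would bear on directly. They also leave open how a phenyl ring carrying an amine or a carboxylic acid would read on this carbon.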